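The compounds below may be only part of what the source reports. "The series", "measured", "known", "first", "only" and "open" are said of these compounds alone.

Compound 1, whose structure is `CSc1ccc(-c2nc3c(=O)n(C)c(=O)n(C)c3[nH]2)cc1`, was tested in an assay for binding affinity to adenosine receptor A1 (Bos taurus) (a higher number here means a weaker inhibitor, a lower number a stronger inhibitor), and there compound 1 gives 2 nM. Within the data shown here, only one other compound has been measured alongside it: compound 2, with the structure `CCn1c(=O)c2nc(-c3ccc(S(=O)(=O)NCCN(C)C)cc3)[nH]c2n(CC)c1=O`, which in this assay gives 3.3 nM. Compound 1 has the lowest of the two numbers, but the two values lie within the usual scatter of each other, so nothing separates the two on this evidence.

The next compound to be examined is compound 3, with the structure `CCCCOc1ccc(-c2nc3c(=O)n(C)c(=O)n(C)c3[nH]2)cc1`. It differs from compound 1 in one place: butoxy in place of methylsulfanyl on an aromatic carbon. Both groups that change hands sit on the same aromatic carbon, and each carries one hydrogen-bond acceptor and no donor, so the exchange mainly trades a short sulfur-containing group for a longer oxygen-containing chain.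

Among the measured compounds shown here, no pair of measured compounds shows what such a change does here. The expectation for the step from compound 1 to compound 3 in this assay is therefore modest, a 1.5-fold higher number from compound 1 to compound 3 (0.18 log units; within the scatter), a shift that need not rise above the scatter. For compound 3 in this assay, the estimated value is 3 nM, with a range from 0.8 nM to 12 nM.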

Compound 3, half-maximal inhibitory concentration: 4 nM
Compound 3: the middle estimate sits 1.3-fold (0.12 log units) below what was measured, within the range that was stated.
By their numbers in this assay, from the lowest: compounds 1, 2 and 3 (each within the scatter of the next).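

In this assay, putting butoxy in place of methylsulfanyl gives a 2.0-fold higher number from compound 1 to compound 3 (0.30 log units; within the scatter), so this step does not separate the two compounds. Among these compounds, this is the first direct reading at this position, on an aromatic carbon para to a large group: the group entering has 5 heavy atoms against 2 for the group leaving, yet the printed step stays within the usual scatter, so the longer oxygen-containing chain shows no clear loss or gain over the short sulfur-containing group in this single comparison. Nothing available explains why the step has this size.

The step also changes the atom attached to the ring and the length of the chain together, so the compounds shown leave open what each change does alone; methoxy, which keeps the oxygen with a single carbon, or butylsulfanyl, which keeps the sulfur with the four-carbon chain, would pull the two apart. They also leave open whether a still longer chain, an amine or a carboxylic acid at this position would give a step beyond the scatter.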